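Two inactive analogues and a dinitrophenyl variant

The source may hold more compounds than are shown below. What is called first, only, known or untested is meant among the compounds shown, and "the series" means these compounds.

compound 1 `N#CC1=C(N)Oc2c(c3nc4ccccc4nc3c3ccccc23)C12C(=O)N(Cc1cnnn1-c1ccccc1Cl)c1ccccc12`: > 50000 nM
compound 2 `CCOc1ccc(-n2nncc2CN2C(=O)C3(C(C#N)=C(N)Oc4c(N)cc5nc6ccccc6nc5c43)c3ccccc32)cc1`: > 50000 nM

In a functional assay on HepG2 cells (Homo sapiens) for antiproliferative activity, read by MTT assay, with a stated time of 48 h (a lower number here means a stronger inhibitor, a higher number a weaker inhibitor), compound 1 gives only a limit, > 50000 nM. Compound 2 likewise reaches only a limit, > 50000 nM. Compound 2 therefore stands at the same edge as every other value in this series, (the limit of > 50000 nM in this assay, at which 2 of the 2 values shown sit). Among the measured compounds shown here, no step between measured compounds can be followed. Compound 3 `N#CC1=C(N)Oc2c(N)cc3nc4ccccc4nc3c2C12C(=O)N(Cc1cnnn1-c1ccc([N+](=O)[O-])cc1[N+](=O)[O-])c1ccccc12` differs from compound 2 by 2,4-dinitrophenyl in place of 4-ethoxyphenyl on an aromatic nitrogen. Without a measured step to lean on, no shift beyond the scatter is expected in this assay. For compound 3 the estimate is 60000 nM, with a range from 20000 nM to 200000 nM, expected to mean a step that the limit leaves unreadable from compound 2 to compound 3 and most likely once more only a limit.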

Compound 3, half-maximal inhibitory concentration: 18400 nM
For compound 3 the middle estimate is 3.3-fold (0.51 log units) above the measured one; the measured number lies below the stated range.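

This aromatic nitrogen is a position where the substituent can move the read-out in this assay: 2,4-dinitrophenyl in place of 4-ethoxyphenyl gives an at least 2.7-fold lower number from compound 2 to compound 3 (0.43 log units; beyond the scatter). Compound 3 is the only compound shown with a number rather than a limit: the limit of > 50000 nM in this assay, at which 2 of the 3 values shown sit. The size of the step remains a bound, not a measured difference.

Going by these compounds, whether one nitro group alone would produce the same step remains open. So does the outcome with an amine or a carboxylic acid in place of the nitro groups on that phenyl ring.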